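Phenyl on the Ring Amine Nitrogen: Compound 3 to Compound 4

This account rests on a few compounds, and the source may have more. Where it says the series, first, only, none or still open, it means among the compounds named here.

Of the compounds shown here, three have been measured in an assay on HEK293 cells for binding affinity to 5-hydroxytryptamine receptor 7 (Homo sapiens), read by radioligand binding, tested at 1 uM; a lower number here means less inhibition, a higher number more inhibition at the concentration tested (going by the name of the read-out). Compound 3 `Brc1ccc2ccn(CCN3CCCNCC3)c2c1` gives 77%, the highest of the three numbers. Compound 1 `Brc1ccc2ccn(CCN3CCC4CCCCN4CC3)c2c1` gives 71%, which sits within the usual scatter of the number for compound 3, so no order between the two can be drawn. Compound 2 `CCc1ccc2ccn(CCN3CCCN(C)CC3)c2c1` gives 66%, beyond the scatter below compound 3; compound 2 differs from compound 3 in more than one place, so the gap cannot be tied to a single change.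

Compound 4 `Brc1ccc2ccn(CCN3CCCN(c4ccccc4)CC3)c2c1` has not yet been measured. It differs from compound 3 by phenyl in place of hydrogen on an amine nitrogen in a ring. Going by the values given here, the two measured compounds that carry a group on that amine nitrogen, compound 1 and compound 2, show numbers that are within the scatter of compound 3 or below it; no measured pair isolates this change.

The expectation for the step from compound 3 to compound 4 is a moderate decrease, a number 15 percentage points lower from compound 3 to compound 4 (beyond the scatter), because compound 2 gives 66% with a substituted ring amine nitrogen while compound 1 with 71% leaves room for no change. Compound 4 is estimated at 62%, within a range of 42% to 80%.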

Compound 4, a percentage reported as inhibition, at one concentration (the size of the read-out at that concentration, not a potency): 18%
The estimate for compound 4 lay 44 percentage points above the measured number, outside the stated range (below it).
By their numbers in this assay, from the lowest: compound 4; then compounds 2, 1 and 3 (each within the scatter of the next, the first and the last beyond it).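

In this assay, going by these compounds alone, phenyl in place of hydrogen on an amine nitrogen in a ring gives a number 59 percentage points lower from compound 3 to compound 4 (beyond the scatter) and forms the first pair that differs in one place only. Within the data shown here, this amine nitrogen of the seven-membered ring is therefore a position where a single change can carry a large step in the read-out, which the earlier compounds, separated by more than one change, could not show. Nothing at hand bears on why phenyl on this nitrogen gives so large a step.

On these data alone, what remains open is which feature of the phenyl group goes with the step: its aromatic ring, its 6 heavy atoms, or its direct attachment to the amine nitrogen. Cyclohexyl or benzyl on that nitrogen, with the rest of compound 3 unchanged, would help to separate these readings, and acetyl would show how a carbonyl attached directly to the same nitrogen compares.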